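The source may report more compounds than this note shows. Statements on the series, on what has been measured and on what is new or still open speak of the compounds shown alone.

Working notes on the series.

Compound 1 `COc1cc2c(Nc3ccc(C#N)cc3)ncnc2cc1OCCCN1CCN(C)CC1` is the reference. In a functional assay on DU-145 cells (Homo sapiens) for antiproliferative activity, read by MTT assay, with a stated time of 72 h (a higher number here means a weaker inhibitor, a lower number a stronger inhibitor), compound 1 gives 46500 nM. Compound 2 `CCN1CCN(CCCOc2cc3ncnc(Nc4ccc(C#N)cc4)c3cc2OC)CC1` differs from compound 1 by methyl in place of hydrogen on a saturated chain carbon bound to an amine nitrogen in a ring, and in this assay compound 2 gives 34400 nM; the step of a 1.4-fold lower number from compound 1 to compound 2 (0.13 log units; within the scatter) is too small to read as a change. Compound 3 `COc1cc2c(Nc3ccccc3C#N)ncnc2cc1OCCCN1CCN(C)CC1` differs from compound 1 in the core, by 2-cyanophenyl in place of 4-cyanophenyl on a nitrogen on an aromatic ring, and in this assay compound 3 gives 19400 nM. The step of a 2.4-fold lower number from compound 1 to compound 3 (0.38 log units; beyond the scatter) is modest but outside the usual scatter. Compound 3 has the lowest number of the three, but its gap to compound 2 lies within the scatter, so no ordering between compound 2 and compound 3 is claimed.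

Compound 4 `CCN1CCN(CCCOc2cc3ncnc(Nc4ccccc4C#N)c3cc2OC)CC1` has not been measured. It differs from compound 3 by methyl in place of hydrogen on a saturated chain carbon bound to an amine nitrogen in a ring. This is the same change as that from compound 1 to compound 2, made on the core of compound 3 rather than the core of compound 1; the two cores differ by 2-cyanophenyl in place of 4-cyanophenyl on a nitrogen on an aromatic ring. Because the measured step of a 1.4-fold lower number from compound 1 to compound 2 (0.13 log units; within the scatter) was within the scatter, the expectation for compound 4 is a step of similar size, a 1.4-fold lower number from compound 3 to compound 4 (0.14 log units; within the scatter), in this assay. This rests on a single measured pair, so the range is kept wide. In this assay compound 4 is expected to give about 14000 nM, with a likely span from 6000 nM to 35000 nM.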

Compound 4, half-maximal inhibitory concentration: 5870 nM
Compound 4: middle estimate off by 2.4-fold (0.38 log units), on the high side; measured number outside the range, below it.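

In this assay, methyl in place of hydrogen on a saturated chain carbon bound to an amine nitrogen in a ring gives a 3.3-fold lower number from compound 3 to compound 4 (0.52 log units; beyond the scatter), and this step does not differ from the earlier one on the core of compound 1 by more than the scatter allows: the same change on two cores in this assay, a 1.4-fold lower number (0.13 log units; within the scatter) from compound 1 to compound 2 and a 3.3-fold lower number (0.52 log units; beyond the scatter) from compound 3 to compound 4, 2.4-fold (0.39 log units) apart, within the scatter of two such steps. The exchange of 4-cyanophenyl for 2-cyanophenyl, read on the 4-ethylpiperazin-1-yl side, gives a 5.9-fold lower number from compound 2 to compound 4 (0.77 log units; beyond the scatter), and it likewise stands within the scatter of its earlier counterpart: the same change on two cores in this assay, a 2.4-fold lower number (0.38 log units; beyond the scatter) from compound 1 to compound 3 and a 5.9-fold lower number (0.77 log units; beyond the scatter) from compound 2 to compound 4, 2.4-fold (0.39 log units) apart, within the scatter of two such steps. Both changes are therefore compatible with carrying over from one core to the other in this assay, but the larger step seen with compound 4 in each pair cannot be read as a real dependence on the core, and a single square of four compounds does not show that either change would transfer to any further core.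

The compounds shown leave open whether a longer chain, such as propyl in place of the ethyl of 4-ethylpiperazin-1-yl, would continue the step seen with methyl to ethyl. They also leave open how a chloro or methoxy group in place of the nitrile on the phenyl would compare.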